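Working notes: compound 4 as a variant of compound 1

The source may report more compounds than this note shows. Statements on the series, on what has been measured and on what is new or still open speak of the compounds shown alone.

In a functional assay on the whole organism with Rattus norvegicus as the target, with a stated time of 4 h, at a dose of 40 mg/kg by the intraperitoneal route (on this read-out higher numbers stand for more inhibition at the one dose given (going by the name of the read-out) and lower numbers for less inhibition), compound 1 `CC(=O)c1c(C)nc2c(OCc3ccccc3)cccn12` gives 57%. Compound 3 `Cc1nc2c(OCc3ccccc3)cccn2c1CS(C)(=O)=O` gives 61%, within the scatter of compound 1, while compound 2 `COCc1c(C)nc2c(OCc3ccccc3)cccn12` gives 99%, well above both. The steps from compound 1 are a number 42 percentage points higher from compound 1 to compound 2 (beyond the scatter) and a number 4 percentage points higher from compound 1 to compound 3 (within the scatter); between the other two, a number 38 percentage points lower from compound 2 to compound 3 (beyond the scatter).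

Compound 4 `Cc1nc2c(OCc3ccccc3)cccn2c1COC(=O)N(C)C` differs from compound 1 as follows: ((dimethylcarbamoyl)oxy)methyl in place of acetyl on an aromatic carbon. The entering group, like methoxymethyl in compound 2, places oxygen on the saturated chain carbon bound to the aromatic carbon, whereas compound 3 carries methylsulfonyl there. The step bearing most on this change is a number 42 percentage points higher from compound 1 to compound 2 (beyond the scatter), so a rise beyond the scatter in this assay is expected, with wide uncertainty. Compound 4 is estimated at 80%, range 55% to 100%. The expected step is a number 23 percentage points higher from compound 1 to compound 4 (beyond the scatter).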

Compound 4, a percentage reported as inhibition, in the whole organism at one dose (the size of the read-out at that dose, not a potency): 75%
For compound 4 the middle estimate is 5 percentage points above the measured one; low and high end bracket the measured number.
By their numbers in this assay, from the lowest: compounds 1 and 3 (each within the scatter of the next); then compound 4; then compound 2.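

In this assay, oxygen on the saturated chain carbon again goes with a higher number than acetyl (a number 18 percentage points higher from compound 1 to compound 4 (beyond the scatter)), and (dimethylcarbamoyl)oxy also stands clear of methylsulfonyl on that carbon (a number 14 percentage points higher from compound 3 to compound 4 (beyond the scatter)). What sits on that oxygen counts as well: dimethylcarbamoyl in place of methyl gives a clear drop (a number 24 percentage points lower from compound 2 to compound 4 (beyond the scatter)), so the oxygen alone does not set the number. No data here account for these differences.

As far as these compounds go, whether hydroxymethyl or aminomethyl in the same place would come nearer to compound 2 or to compound 4 stays open.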